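The source may report more compounds than this note shows. Statements on the series, on what has been measured and on what is new or still open speak of the compounds shown alone.

Measured so far in a functional assay on SW 1116 cells (Homo sapiens) for antiproliferative activity, read by MTT assay, with a stated time of 24 h; a higher number here means a weaker inhibitor, a lower number a stronger inhibitor:
Compound 1, `Sc1nnc(-c2ccc3c(c2)OCCO3)n1-c1ccccc1`, gives 38400 nM.
Compound 2, `O=[N+]([O-])c1ccccc1CSc1nnc(-c2ccc3c(c2)OCCO3)n1-c1ccccc1`, gives 8300 nM.
Compound 3, `Brc1ccccc1CSc1nnc(-c2ccc3c(c2)OCCO3)n1-c1ccccc1`, gives 7350 nM.

Compound 2 stands second highest of these three numbers. Its nearest neighbour is compound 3, within the usual scatter (a 1.1-fold lower number from compound 2 to compound 3 (0.05 log units; within the scatter)), and the furthest is compound 1, a gap beyond the scatter (a 4.6-fold lower number from compound 1 to compound 2 (0.67 log units; beyond the scatter)).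

Compound 4, `Brc1ccc(CSc2nnc(-c3ccc4c(c3)OCCO4)n2-c2ccccc2)cc1`, has not yet been measured in this assay. It differs from compound 2 in one place: 4-bromophenyl in place of 2-nitrophenyl on a saturated chain carbon bound to a sulfur. Two kinds of measured step bear on this. Replacing the hydrogen on the sulfur by either benzyl group lowered the number modestly, a 4.6-fold lower number from compound 1 to compound 2 (0.67 log units; beyond the scatter) and a 5.2-fold lower number from compound 1 to compound 3 (0.72 log units; beyond the scatter). Exchanging bromo for nitro on the aromatic carbon gave nothing beyond the scatter, a 1.1-fold lower number from compound 2 to compound 3 (0.05 log units; within the scatter). Within the data shown here, compound 4 keeps a benzyl on the sulfur and carries a bromine; no measured pair speaks to where on the ring the bromine sits. The step from compound 2 is therefore expected to stay within the scatter, a 1.1-fold lower number from compound 2 to compound 4 (0.04 log units; within the scatter). Compound 4 is estimated at 7500 nM, with a range from 3500 nM to 16000 nM.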

Compound 4, half-maximal inhibitory concentration: 5810 nM
Beside the measured number, compound 4's estimate is 1.3-fold (0.11 log units) above it; the measured number falls inside the stated range.
By their numbers in this assay, from the lowest: compounds 4, 3 and 2 (each within the scatter of the next); then compound 1.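

In this assay, moving the bromine around the ring gives a 1.3-fold lower number from compound 3 to compound 4 (0.10 log units; within the scatter), the first measured sign that its place on the ring makes no difference beyond the scatter here. Replacing 2-nitrophenyl with 4-bromophenyl gives a 1.4-fold lower number from compound 2 to compound 4 (0.15 log units; within the scatter) and so also stays within the scatter, while replacing the hydrogen on the sulfur with 4-bromobenzyl gives a 6.6-fold lower number from compound 1 to compound 4 (0.82 log units; beyond the scatter) and so joins the other two benzyl groups in lowering the number beyond the scatter. No measurement available here explains why these benzyl groups read alike.

From the compounds shown here alone, it remains open whether a plain benzyl with nothing on its ring, or a simple ethyl chain on the sulfur, would lower the number as far. Going by these compounds, it is also open whether an amine or a carboxylic acid on the benzyl ring would keep the number in this range.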